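Amide-side substituent change in a pyrazine indole series

This account rests on a few compounds, and the source may have more. Where it says the series, first, only, none or still open, it means among the compounds named here.

Measured so far:
compound 1 `CNS(=O)(=O)c1ccccc1Nc1cc(-c2ccc3ccn(C)c3c2)c2nccnc2c1` 104 nM
compound 2 `CN(Cc1cncnc1)S(=O)(=O)c1ccccc1Nc1cc(-c2ccc3ccn(C)c3c2)c2nccnc2c1` 62 nM
compound 3 `Cn1ccc2ccc(-c3cc(Nc4cnccc4C(=O)NCc4cncnc4)cc4nccnc34)cc21` 106 nM

Compound 3 carries the highest of the three numbers in an assay for inhibition of 6-phosphofructo-2-kinase/fructose-2,6-bisphosphatase 3 (Homo sapiens), read by ADP-Glo, with a stated time of 2 h (on this read-out higher numbers stand for weaker inhibition and lower numbers for stronger inhibition), but its gap to compound 1 and to compound 2 is within the scatter, so nothing separates the three on potency. Among the measured compounds shown here, the only step between compounds that differ in one place is a 1.7-fold lower number from compound 1 to compound 2 (0.22 log units; within the scatter), a change on the sulfonamide nitrogen of the shared core.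

Compound 4 `CN1CC(NC(=O)c2ccncc2Nc2cc(-c3ccc4ccn(C)c4c3)c3nccnc3c2)CCC1=O` is not yet measured. It differs from compound 3 in that (1-methyl-6-oxopiperidin-3-yl in place of (pyrimidin-5-yl)methyl on an amide-type nitrogen). For the measured compounds named here, no measured pair shows this change, and the one step in hand concerns a different nitrogen and a different pair of groups; it only shows that adding (pyrimidin-5-yl)methyl there left the number within the scatter. Going by the values given here, with nothing further to lean on, the expectation for the step from compound 3 to compound 4 is a 1.0-fold higher number from compound 3 to compound 4 (0.02 log units; within the scatter), that is, no step beyond the scatter in either direction, with the range kept wide because the entering group has no precedent. Compound 4 is therefore expected to give about 110 nM in this assay, between 35 nM and 350 nM.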

Compound 4, half-maximal inhibitory concentration: 116 nM
Estimate against measurement, compound 4: 1.1-fold (0.02 log units) below; low and high end bracket the measured number.
By their numbers in this assay, from the lowest: compounds 2, 1, 3 and 4 (each within the scatter of the next).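

Among the compounds shown here, on the amide-type nitrogen in this assay, 1-methyl-6-oxopiperidin-3-yl in place of (pyrimidin-5-yl)methyl gives a 1.1-fold higher number from compound 3 to compound 4 (0.04 log units; within the scatter), the first step in hand at this position, whereas the earlier step concerned only the sulfonamide nitrogen. This position therefore accepts a six-membered non-aromatic ring with one hetero atom and a carbonyl in place of a six-membered aromatic ring with two hetero atoms, with no step beyond the scatter, even though the hydrogen-bond acceptor count of the group changes. No measurement in hand accounts for this lack of separation between the two groups.

The compounds shown leave open whether a plain methyl, a 2-(dimethylamino)ethyl chain or a group carrying a carboxylic acid on this amide-type nitrogen would give a step beyond the scatter, since the two groups compared here both hold a six-membered ring. Also open, on these data alone, is how 1-methyl-6-oxopiperidin-3-yl would behave on the sulfonamide nitrogen, and so whether the two nitrogens respond alike to the same group.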